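This account rests on a few compounds, and the source may have more. Where it says the series, first, only, none or still open, it means among the compounds named here.

Measured compounds in a functional assay on SK-OV-3 cells (Homo sapiens) for cytotoxicity, read by MTT assay, with a stated time of 48 h; on this read-out higher numbers stand for weaker inhibition and lower numbers for stronger inhibition:
Compound 1 `O=C(/C=C/c1ccc2c(c1)B(O)OC2)c1ccccc1` gives 3400 nM.
Compound 2 `O=C(/C=C/c1ccc2c(c1)B(O)OC2)c1ccco1` gives 20700 nM.
Compound 3 `O=C(/C=C/c1ccc2c(c1)B(O)OC2)c1cccs1` gives 10400 nM.

Compound 1 stands lowest of the three numbers in this assay; the nearest is compound 3 and the furthest is compound 2, both at a distance beyond the scatter. Compound 4 `Cn1cccc1C(=O)/C=C/c1ccc2c(c1)B(O)OC2` shares the core of compound 1 and differs from it in one place: 1-methyl-1H-pyrrol-2-yl in place of phenyl on a carbonyl carbon.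

Going by the values given here, two measured steps bear on this change, since both replace the phenyl on the carbonyl carbon with a five-membered aromatic ring carrying one hetero atom. The step of a 6.1-fold higher number from compound 1 to compound 2 (0.78 log units; beyond the scatter) and the step of a 3.1-fold higher number from compound 1 to compound 3 (0.49 log units; beyond the scatter) both moved in the same direction, towards weaker inhibition. The two heteroaryl compounds themselves differ by a 2.0-fold lower number from compound 2 to compound 3 (0.30 log units; within the scatter), so no order between compound 2 and compound 3 can be read from these numbers.

On this basis compound 4 is expected to give a higher number than compound 1, a step of roughly the size seen for the other five-membered rings, estimated as a 2.9-fold higher number from compound 1 to compound 4 (0.47 log units; beyond the scatter). The value expected for compound 4 in this assay is 10000 nM, with a range from 3500 nM to 30000 nM.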

Compound 4, half-maximal inhibitory concentration: 93600 nM
The estimate for compound 4 lay 9.4-fold (0.97 log units) below the measured number; the whole stated range lies below it.
By their numbers in this assay, from the lowest: compound 1; then compounds 3 and 2 (each within the scatter of the next); then compound 4.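

In this assay the place on the carbonyl carbon proves much less forgiving than the furan-2-yl and thiophen-2-yl compounds indicated: 1-methyl-1H-pyrrol-2-yl in place of phenyl gives a 28-fold higher number from compound 1 to compound 4 (1.44 log units; beyond the scatter), a large step where the two earlier replacements were modest. The new group also stands apart from the other five-membered rings, with a 9.0-fold higher number from compound 3 to compound 4 (0.95 log units; beyond the scatter) and a 4.5-fold higher number from compound 2 to compound 4 (0.66 log units; beyond the scatter), so a five-membered aromatic ring with one hetero atom does not by itself set the number here, and compound 4 is the weakest of the four, even though phenyl and 1-methyl-1H-pyrrol-2-yl carry the same count of heavy atoms. Nothing available here accounts for the size of this step.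

The compounds shown cannot separate the contribution of the methyl on the ring nitrogen from that of the ring itself, a question that an unsubstituted 1H-pyrrol-2-yl group would address. They also leave open how a pyridine ring, or a phenyl ring carrying an amine or a carboxylic acid, would stand on this carbonyl carbon.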